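Methoxy for Methyl on the Benzyl Arm of Compound 2

This account rests on a few compounds, and the source may have more. Where it says the series, first, only, none or still open, it means among the compounds named here.

Measured compounds:
compound 1, `CCN1CCN(CC(=O)Nc2ccc(-c3nc(-c4ccccc4)c(-c4ccccc4)n3C)cc2)CC1`, a functional assay on HT-29 cells (Homo sapiens) for cytotoxicity, read by MTT assay, with a stated time of 24 h, tested at 16 ug/mL; a higher number here means a stronger effect of the compound at the concentration tested, a lower number a weaker effect: 28.4%
compound 2, `Cc1ccc(CN2CCN(CC(=O)Nc3ccc(-c4nc(-c5ccccc5)c(-c5ccccc5)n4C)cc3)CC2)cc1`, this assay: 30.6%

For the measured compounds named here, compound 2 holds the higher of the two numbers in this assay, yet compound 1, its only neighbour, sits within the scatter of it, so the two cannot be ordered. Going by the values given here, the single measured step, a number 2.2 percentage points higher from compound 1 to compound 2 (within the scatter), placed 4-methylphenyl in place of methyl on a saturated chain carbon bound to an amine nitrogen in a ring and did not move the read-out beyond the scatter.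

Compound 3, `COc1ccc(CN2CCN(CC(=O)Nc3ccc(-c4nc(-c5ccccc5)c(-c5ccccc5)n4C)cc3)CC2)cc1`, differs from compound 2 by methoxy in place of methyl on an aromatic carbon. Neither measured step touches the substituent on this outer six-membered ring, so nothing in the data speaks directly to exchanging methyl for methoxy there. Among the compounds with values here, the one change that was measured, on a nearby part of the molecule, left the read-out essentially unchanged, and the same is expected here: the step of a number 0.6 percentage points lower from compound 2 to compound 3 (within the scatter) is estimated to lie within the scatter. Compound 3 is therefore expected to give about 30% in this assay, with a likely range from 18% to 42%.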

Compound 3, a percentage reported as activity, at one concentration (the size of the read-out at that concentration, not a potency): 21.8%
Estimate against measurement, compound 3: 8.2 percentage points above; the range from low to high includes it.
By their numbers in this assay, from the lowest: compounds 3, 1 and 2 (each within the scatter of the next).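

For the compounds shown here, this is the first measured change on the outer ring itself. In this assay, methoxy in place of methyl on an aromatic carbon, para to a large group, gave a step that cannot be told from the scatter (a number 8.8 percentage points lower from compound 2 to compound 3 (within the scatter)), so exchanging these two groups at this position has no measurable consequence in this read-out. The comparison with the smaller arm agrees (a number 6.6 percentage points lower from compound 1 to compound 3 (within the scatter)): the 4-methoxybenzyl arm, like the 4-methylbenzyl arm, cannot be separated from compound 1, all three compounds remain unordered, and nothing available here accounts for the numbers.

The compounds shown leave open whether any other group on this aromatic carbon, such as a chlorine atom, a hydroxyl or a dimethylamino group, would give a step beyond the scatter, and whether a longer chain between the aromatic ring and the amine nitrogen would do so. Each number comes from one concentration, so they also leave open whether these compounds would give a stronger or weaker effect at any other concentration.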